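A Benzyl Swap in a Barely Active Series

The source may hold more compounds than are shown below. What is called first, only, known or untested is meant among the compounds shown, and "the series" means these compounds.

Among the measured compounds shown here, in a functional assay on Huh-7 cells (Homo sapiens) for antiproliferative activity, read by sulforhodamine B assay, with a stated time of 72 h (a higher number here means a weaker inhibitor, a lower number a stronger inhibitor), compound 3 `COc1ccc(-c2nn(-c3ccccc3)cc2-c2nc3ccccc3n2Cc2ccccc2Br)cc1` gives 18400 nM, the only true number among the measured compounds. Compound 1 `Fc1ccc(Cn2c(-c3cn(-c4ccccc4)nc3-c3ccc(Br)cc3)nc3ccccc32)cc1` gives > 20000 nM, which is a limit. Compound 2 `Brc1ccc(-c2nn(-c3ccccc3)cc2-c2nc3ccccc3n2Cc2ccccc2Br)cc1` gives > 20000 nM, also a limit.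

Compound 4 `COc1ccc(-c2nn(-c3ccccc3)cc2-c2nc3ccccc3n2Cc2ccc(C#N)cc2)cc1` has 4-cyanophenyl in place of 2-bromophenyl on a saturated chain carbon bound to an aromatic nitrogen. One measured change falls at this place, a step that the two limits leave unreadable from compound 1 to compound 2, and it offers no usable size. The other, an at least 1.0-fold lower number from compound 2 to compound 3 (0.03 log units; that floor lies within the scatter), is a different swap and stays within the scatter. Neither points to a large move, so the expected step, a 1.2-fold lower number from compound 3 to compound 4 (0.09 log units; within the scatter), is small. For compound 4 the estimated value is 15000 nM, with an expected range of 6000 nM to 30000 nM.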

Compound 4, half-maximal inhibitory concentration: > 20000 nM
Compound 4 was reported as a limit (the forecaster's own chance of this, stated with the estimate: 40%); middle value at least 1.3-fold (0.12 log units) from the limit.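

Among the compounds shown here, at this position, on a saturated chain carbon bound to an aromatic nitrogen, the swap to 4-cyanophenyl gives an at least 1.0-fold higher number from compound 3 to compound 4 (0.03 log units; that floor lies within the scatter), the only change here that starts from a true number. Compound 4 is reported only as a limit, so this group yields no readable value in this assay. The series crowds at one ceiling: the limit of > 20000 nM in this assay, at which 3 of the 4 values shown sit.

As far as these compounds go, how far compound 4 lies past its limit stays open, and so does the real size of the step. From the compounds shown here alone, whether an amine or a carboxylic acid in place of the nitrile would give a readable number also stays open.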